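Amino-linked phenyl substituents and cytotoxicity in the shared core

The source may hold more compounds than are shown below. What is called first, only, known or untested is meant among the compounds shown, and "the series" means these compounds.

Compound 1 `FC(F)(F)c1ccc(CSc2nc(Nc3ccccc3)c3ccccc3n2)cc1` carries an unsubstituted phenyl on the amine of the shared core; in a functional assay on MDA-MB-231 cells (Homo sapiens) for cytotoxicity, read by MTT assay, with a stated time of 72 h (on this read-out lower numbers stand for stronger inhibition and higher numbers for weaker inhibition), compound 1 gives 18400 nM. Compound 2 `FC(F)(F)c1ccc(CSc2nc(Nc3ccccc3C(F)(F)F)c3ccccc3n2)cc1` adds a trifluoromethyl to that ring. In this assay compound 2 gives only the limit > 50000 nM. Compound 3 `COc1ccccc1Nc1nc(SCc2ccc(C(F)(F)F)cc2)nc2ccccc12` instead carries a methoxy. In this assay compound 3 also gives only the limit > 50000 nM, so compound 3 sits at the weak end of the values shown, at the limit of > 50000 nM in this assay, at which 2 of the 3 values shown sit. Both substitutions read weaker than compound 1: an at least 2.7-fold higher number from compound 1 to compound 2 (0.43 log units; beyond the scatter) and an at least 2.7-fold higher number from compound 1 to compound 3 (0.43 log units; beyond the scatter); between them, a step that the two limits leave unreadable from compound 2 to compound 3. Compound 4 `FC(F)(F)c1ccc(CSc2nc(Nc3cccc(C(F)(F)F)c3)c3ccccc3n2)cc1` is the change (3-(trifluoromethyl)phenyl in place of 2-methoxyphenyl on a nitrogen on an aromatic ring). Going by the values given here, with no measured precedent for that placement, compound 4 is expected near the limit, estimated at 40000 nM (range 12000 nM to 120000 nM), which would mean an at least 1.2-fold lower number from compound 3 to compound 4 (0.09 log units; that floor lies within the scatter).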

Compound 4, half-maximal inhibitory concentration: 11100 nM
The estimate for compound 4 lay 3.6-fold (0.56 log units) above the measured number; measured number below the stated range.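

In this assay, 3-(trifluoromethyl)phenyl in place of 2-(trifluoromethyl)phenyl on the nitrogen gives an at least 4.5-fold lower number from compound 2 to compound 4 (0.65 log units; beyond the scatter), so the same group does not read alike at both placements. The step of an at least 4.5-fold lower number from compound 3 to compound 4 (0.65 log units; beyond the scatter) likewise starts from a limit of the assay, as does the one before it: the limit of > 50000 nM in this assay, at which 2 of the 4 values shown sit. Against the unsubstituted phenyl the step is a 1.7-fold lower number from compound 1 to compound 4 (0.22 log units; within the scatter), so a trifluoromethyl on this ring need not weaken the read-out, and no gain is shown.

Open, from the compounds shown here alone, is how a nitrile or a carboxylic acid would read in place of the trifluoromethyl of compound 4.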